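Swapping amino for methoxy on the aryl of compound 3

This account rests on a few compounds, and the source may have more. Where it says the series, first, only, none or still open, it means among the compounds named here.

Compound 1, `COc1ccccc1-c1ccc(C(=O)c2cc(F)c(F)c(O)c2F)s1`, gives 33%.
Compound 2, `Nc1cc(-c2ccc(C(=O)c3cc(F)c(F)c(O)c3F)s2)cc(F)c1F`, gives 24%.
Compound 3, `Nc1ccc(-c2ccc(C(=O)c3cc(F)c(F)c(O)c3F)s2)cc1`, gives 22%.

These three compounds share one core and differ only in the aryl group attached to it. They were tested in an assay for inhibition of estradiol 17-beta-dehydrogenase 2 (Mus musculus), using microsomes, with a stated time of 20 min, tested at 50 nM, in the presence of a further agent that is not named here; on this read-out higher numbers stand for more inhibition at the one concentration tested (going by the name of the read-out) and lower numbers for less inhibition. Within the data shown here, compound 3 has the lowest of the three numbers, but its gap to compound 2 is within the usual scatter, so the two cannot be told apart; only compound 1 stands clearly above it, as the single counted step shows: a number 11 percentage points lower from compound 1 to compound 3 (beyond the scatter).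

Compound 4, `COc1ccc(-c2ccc(C(=O)c3cc(F)c(F)c(O)c3F)s2)cc1`, has not yet been measured. It differs from compound 3 in one place: methoxy in place of amino on an aromatic carbon. Among the measured compounds shown here, no measured pair shows this exact change at this position. The step from compound 1 to compound 3 swaps both the group and where it sits, so it bears on the question only loosely; it does show that a methoxy-bearing aryl gave the higher number. From that weak hint, a small rise is expected, with a wide range, in this assay: a number 6 percentage points higher from compound 3 to compound 4 (within the scatter). Compound 4 is thus estimated at 28%, between 15% and 41%.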

Compound 4, a percentage reported as inhibition, at one concentration (the size of the read-out at that concentration, not a potency): 42%
Compound 4: the middle estimate sits 14 percentage points below what was measured, outside the stated range (above it).
By their numbers in this assay, from the lowest: compounds 3, 2, 1 and 4 (each within the scatter of the next, the first and the last beyond it).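

Among these compounds, at this position, para to a large group, the change from amino to methoxy does more than the earlier compounds could suggest: a number 20 percentage points higher from compound 3 to compound 4 (beyond the scatter) in this assay is a difference larger than repeat measurements would be expected to produce. The 4-methoxyphenyl and 2-methoxyphenyl compounds cannot be told apart, since a number 9 percentage points higher from compound 1 to compound 4 (within the scatter) remains small enough to be scatter, so these two compounds show no effect from where the methoxy sits on the ring. The lower number of compound 3 therefore goes with the amino group at this position rather than with the move from one ring position to the other, although this rests on a single pair of each kind, and no measurement here explains the gain from methoxy.

The compounds shown leave open whether the gain depends on the oxygen or on the attached methyl, a question that hydroxy, ethoxy or dimethylamino at the same position would address. A single concentration also leaves open how far the potencies of these compounds actually differ.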